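The source may hold more compounds than are shown below. What is called first, only, known or untested is meant among the compounds shown, and "the series" means these compounds.

Measured so far:
Compound 1 `Cc1ncc(C)c(-c2ccccc2)n1` gives 12% in a functional assay on the whole organism for inhibition, with Rattus norvegicus as the target, with stated times of 1 h and 3.5 h, at a dose of 100 mg/kg by the oral route; a lower number here means less inhibition, a higher number more inhibition at the dose given (going by the name of the read-out).
Compound 2 `Cc1cncnc1-c1ccncc1` gives 50% in this assay.
Compound 3 `CC(C)(C)c1nc(-c2ccccc2)ncc1-c1ccccc1` gives < 5% in this assay.

Compound 3 stands at the floor of the measurements: its value is a limit of the assay, not a number, as the limit of < 5% in this assay, at which 1 of the 3 values shown sits, records. Within the data shown here, compound 1 sits higher, and compound 2 higher still, with no step between them described.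

Compound 4 `CC(C)(C)c1nc(NN)ncc1-c1ccccc1` has not yet been measured. It differs from compound 3 as follows: aminoamino in place of phenyl on an aromatic carbon.

Among the measured compounds shown here, no step between measured compounds is available to set the size of this change. The account expects compound 4 to rise from the limit by a number at least 15 percentage points higher from compound 3 to compound 4 (beyond the scatter), a step beyond the scatter but modest. The estimate for compound 4 in this assay is 20%, in a range from 5% to 45%.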

Compound 4, a percentage reported as inhibition, in the whole organism at one dose (the size of the read-out at that dose, not a potency): < 5%
Compound 4: a limit, no number; the forecaster's own chance of this, stated with the estimate: 35%; middle value at least 15 percentage points from the limit.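

Compound 3 and compound 4 both rest on a limit of the assay, not a number, so no step between them can be read: the limit of < 5% in this assay, at which 2 of the 4 values shown sit.

The compounds shown leave open whether aminoamino in place of phenyl changes the result in this assay at all.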